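The source may hold more compounds than are shown below. What is called first, only, known or untested is meant among the compounds shown, and "the series" means these compounds.

Measured so far in a functional assay on BMDM cells (Mus musculus, strain C57BL/6) for inhibition, with a stated time of 2 days; a lower number here means a stronger inhibitor, a higher number a weaker inhibitor:
compound 1, `O=C(Cn1cc(-c2ccc([N+](=O)[O-])cc2)nn1)Nc1nccs1`: 1040 nM
compound 2, `COc1ccc(-c2cn(CC(=O)Nc3nccs3)nn2)cc1`: 510 nM
compound 3, `Nc1cccc(-c2cn(CC(=O)Nc3nc4ccccc4s3)nn2)c1`: 1110 nM

Compound 2 holds the lowest of the three numbers in this assay. Going by the values given here, the only step between two compounds that differ in one place is a 2.0-fold lower number from compound 1 to compound 2 (0.31 log units; beyond the scatter), with methoxy in place of nitro on an aromatic carbon. Compound 3 differs from compound 2 in two places, so only its value is set beside that of compound 2, and it is higher by a margin beyond the scatter.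

Compound 4, `COc1ccc(-c2cn(CC(=O)Nc3cc(C)on3)nn2)cc1`, differs from compound 2 by 5-methyl-1,2-oxazol-3-yl in place of 1,3-thiazol-2-yl on an amide-type nitrogen. Among the compounds with values here, no measured step touches the group on the amide-type nitrogen; the single measured step concerns the aromatic carbon and gives no guide here. Within the data shown here, with no precedent, no shift beyond the scatter is expected in either direction, and the range is kept wide. For compound 4 the expected number in this assay is 700 nM, between 250 nM and 2500 nM. The estimated step is a 1.4-fold higher number from compound 2 to compound 4 (0.14 log units; within the scatter).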

Compound 4, half-maximal inhibitory concentration: > 30000 nM
Compound 4 ended at the assay's limit; the forecaster's own chance of this, stated with the estimate: 10%; middle value at least 42-fold (1.63 log units) from the limit.
By their numbers in this assay, from the lowest: compound 2; then compounds 1 and 3 (each within the scatter of the next). At a limit, above all of these: compound 4.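

Compound 4 stands at a limit of this assay, not at a number: the limit of > 30000 nM in this assay, at which 1 of the 4 values shown sits. Going by these compounds alone, the change on the amide-type nitrogen gives an at least 58-fold higher number from compound 2 to compound 4 (1.76 log units; beyond the scatter), which makes this place far more sensitive than the aromatic carbon, where the only earlier step was a 2.0-fold lower number from compound 1 to compound 2 (0.31 log units; beyond the scatter) and activity remained measurable. The groups that leave and enter are each one five-membered aromatic ring with 2 hetero atoms, and each has 0 hydrogen-bond donors and 2 hydrogen-bond acceptors, so these shared counts do not suffice to keep the activity of compound 2.

The compounds shown do not separate the exchange of the ring from the added methyl. A 1,2-oxazol-3-yl without the methyl and a 1,3-thiazol-2-yl carrying a methyl would divide the two contributions.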